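From 3-methylphenyl to 4-methylphenyl: an expected step

The source may hold more compounds than are shown below. What is called first, only, known or untested is meant among the compounds shown, and "the series" means these compounds.

Measured so far in an ADME assay on HUVEC cells (Homo sapiens) for cytotoxicity, read by MTT assay, with a stated time of 24 h (on this read-out lower numbers stand for higher toxicity in this test and higher numbers for lower toxicity in this test), are these
- compound 1 `Cc1ccccc1/C=C/c1nnc(-c2ccc3c(c2)OCCO3)o1` gives 356000 nM
- compound 2 `Cc1cccc(/C=C/c2nnc(-c3ccc4c(c3)OCCO4)o2)c1` gives 201000 nM

Compound 2 at 201000 nM stands within the scatter of compound 1, and the two cannot be ranked. Compound 3 `Cc1ccc(/C=C/c2nnc(-c3ccc4c(c3)OCCO4)o2)cc1` differs from compound 2 by one change 4-methylphenyl in place of 3-methylphenyl on a double-bonded chain carbon bound to a double-bonded chain carbon with 4-methylphenyl in place of 3-methylphenyl on a double-bonded chain carbon bound to a double-bonded chain carbon. Within the data shown here, the only measured step bearing on it is a 1.8-fold lower number from compound 1 to compound 2 (0.25 log units; within the scatter) for a swap of methylphenyl groups at that same place. No step beyond the scatter is therefore expected in this assay here. The estimated 1.2-fold higher number from compound 2 to compound 3 (0.09 log units; within the scatter) is accordingly small. For compound 3 the expected value is 250000 nM with a range from 120000 nM to 500000 nM in this estimate.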

Compound 3, half-maximal cytotoxic concentration: 265000 nM
For compound 3 the middle estimate is 1.1-fold (0.03 log units) below the measured one, within the range that was stated.
By their numbers in this assay, from the lowest: compounds 2, 3 and 1 (each within the scatter of the next).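

In this assay the 4-methylphenyl group, on a double-bonded chain carbon bound to a double-bonded chain carbon, gives a 1.3-fold higher number from compound 2 to compound 3 (0.12 log units; within the scatter) and a 1.3-fold lower number from compound 1 to compound 3 (0.13 log units; within the scatter) and so joins the other two methylphenyl groups within the scatter. At this place, then, the 2-methylphenyl, 3-methylphenyl and 4-methylphenyl groups cannot be told apart in this test. Nothing measured here offers an explanation for this. The compounds shown leave open whether an amine, a carboxylic acid or a longer chain on that phenyl ring would give a step beyond the scatter.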